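This account rests on a few compounds, and the source may have more. Where it says the series, first, only, none or still open, it means among the compounds named here.

Working notes on the azide-linker series.

Compound 1 `COC(=O)c1cccc(COc2c(-c3ccc(OCCOCCOCCN=[N+]=[N-])cc3)oc3ccccc3c2=O)c1` carries the longer chain ending in the azide. In an ADME assay on L929 cells (Mus musculus) for cytotoxicity (a lower number here means a stronger inhibitor, a higher number a weaker inhibitor), compound 1 gives 28400 nM. Among the measured compounds shown here, this is the only number the series has so far; the second value is a limit rather than a measurement, so compound 1 cannot be ranked against anything yet.

Compound 2 `COC(=O)c1cccc(COc2c(-c3ccc(OCCOCCOCCn4cc(CN(C)Cc5ccccc5)nn4)cc3)oc3ccccc3c2=O)c1` is the triazole-linked benzylamine. In this assay compound 2 reaches only the limit of the assay, > 100000 nM. The shape of the data in this assay is therefore (the limit of > 100000 nM in this assay, at which 1 of the 2 values shown sits); what compound 1 and compound 2 show is one number and one limit, and nothing more is drawn from the pair.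

Compound 3 `COC(=O)c1cccc(COc2c(-c3ccc(OCCOCCN=[N+]=[N-])cc3)oc3ccccc3c2=O)c1` is not yet measured in this assay. Relative to compound 1 it shows (azido in place of 2-azidoethoxy on a saturated chain carbon, two bonds along the chain from an oxygen on a saturated carbon). For the measured compounds named here, the series offers no measured step in which only the linker length changes, so the expectation rests on compound 1 alone. The step from compound 1 to compound 3 is expected to be a 1.1-fold higher number from compound 1 to compound 3 (0.02 log units; within the scatter), none beyond the scatter in either direction. For compound 3 the estimated half-maximal inhibitory concentration in this assay is 30000 nM, with a range of 12000 nM to 80000 nM.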

Compound 3, half-maximal inhibitory concentration: 67500 nM
Compound 3: the middle estimate sits 2.3-fold (0.35 log units) below what was measured; the measured number falls inside the stated range.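

The series now has its first measured step at this position: azido in place of 2-azidoethoxy on a saturated chain carbon, two bonds along the chain from an oxygen on a saturated carbon, gives a 2.4-fold higher number from compound 1 to compound 3 (0.38 log units; beyond the scatter) in this assay. With the azide end and the shared core kept, chain length therefore matters here, and the shorter chain of compound 3 is the weaker inhibitor of the pair, by a modest step. Compound 2 remains the only compound at a limit rather than a number, so it adds no step to this comparison: the limit of > 100000 nM in this assay, at which 1 of the 3 values shown sits.

A single step cannot establish a trend with chain length, and a longer chain ending in the azide would show whether the number falls further as the chain grows. On these data alone, it also remains open whether the same shortening carries the same step when the azide is replaced by a triazole bearing a benzylamine, or by a primary amine at the chain end.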